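Compound 4: Swapping Amino for 4-Methylpiperazin-1-yl

The source may report more compounds than this note shows. Statements on the series, on what has been measured and on what is new or still open speak of the compounds shown alone.

In a physicochemical assay for solubility, read by HPLC, using the shake flask method, in phosphate buffer, with a stated time of 20 h, at pH 6.5 (on this read-out lower numbers stand for lower solubility and higher numbers for higher solubility), compound 3 (`NCC1CCN(c2nccc3[nH]c(-c4cccc(OC(F)(F)F)c4)nc23)CC1`) gives 200000 nM and compound 2 (`NC1CCN(c2nccc3[nH]c(-c4cccc(OC(F)(F)F)c4)nc23)CC1`) gives 200000 nM on the same scale. In this assay compound 1 (`CN1CCN(CC2CCN(c3nccc4[nH]c(-c5ccc(F)c(F)c5)nc34)CC2)CC1`) gives 195000 nM and so sits level with them within the usual scatter of repeat measurements. Compound 3 therefore stands inside one tight group of three numbers.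

Compound 4 (`CN1CCN(CC2CCN(c3nccc4[nH]c(-c5cccc(OC(F)(F)F)c5)nc34)CC2)CC1`) differs from compound 3 at one place, on a saturated chain carbon bound to a saturated ring carbon. The change reads 4-methylpiperazin-1-yl in place of amino on a saturated chain carbon bound to a saturated ring carbon and, cut one bond further out, it is aminomethyl to (4-methylpiperazin-1-yl)methyl.

For the measured compounds named here, the one measured step that bears on this group is aminomethyl in place of amino on a saturated ring carbon, which gave no change at the digits printed from compound 2 to compound 3 (within the scatter) and stayed within the scatter. It is a far smaller change than this one, so it offers only limited guidance. Compound 1 also carries 4-methylpiperazin-1-yl, though it differs elsewhere, and compound 1 gives 195000 nM in the same group of numbers. No measurement covers this exact change, so some room for a drop is kept. The expected step of a 1.1-fold lower number from compound 3 to compound 4 (0.05 log units; within the scatter) stays within the scatter. For compound 4 the estimated value is 180000 nM with an expected range from 90000 nM to 210000 nM in this assay as the test.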

Compound 4, solubility: 200000 nM
Compound 4: the middle estimate sits 1.1-fold (0.05 log units) below what was measured; the measured number falls inside the stated range.
By their numbers in this assay, from the lowest: compounds 1, 2, 3 and 4 (each within the scatter of the next).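

In this assay, putting 4-methylpiperazin-1-yl in place of amino on a saturated chain carbon bound to a saturated ring carbon swaps 1 heavy atom for 7 heavy atoms and adds a six-membered non-aromatic ring, yet the result is no change at the digits printed from compound 3 to compound 4 (within the scatter) and this tests the position with a far larger swap than the earlier step did. Taken one bond further in, the swap read at the saturated ring carbon gives no change at the digits printed from compound 2 to compound 4 (within the scatter) and, with that side group held constant, 3-(trifluoromethoxy)phenyl in place of 3,4-difluorophenyl on an aromatic carbon gives a 1.0-fold higher number from compound 1 to compound 4 (0.01 log units; within the scatter) as the first direct comparison at that aromatic carbon. Neither the side group nor the aromatic group, each changed on its own, separates these compounds in this assay, and no measured evidence is available to explain this result.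

On these data alone, whether a carboxylic acid or a morpholin-4-yl group in place of amino on that saturated chain carbon would give a similar number remains open. So does the outcome for a longer chain carrying 4-methylpiperazin-1-yl on the same saturated ring carbon.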